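Trading hydroxy for fluoro on a benzyl amide

The source may hold more compounds than are shown below. What is called first, only, known or untested is meant among the compounds shown, and "the series" means these compounds.

In a functional assay on MCF7 cells (Homo sapiens) for inhibition, read by MTT assay (on this read-out lower numbers stand for stronger inhibition of growth and higher numbers for weaker inhibition of growth), compound 1 `CC1=C(/C=C/C(C)=C/C=C/C(C)=C\C(=O)Nc2ccc(F)cc2)C(C)(C)CCC1n1ccnc1` reads 400 nM while compound 2 `CC1=C(/C=C/C(C)=C/C=C/C(C)=C\C(=O)NCc2ccc(O)cc2)C(C)(C)CCC1n1ccnc1` has the lower number at 160 nM and so leads this pair. Compound 3 `CC1=C(/C=C/C(C)=C/C=C/C(C)=C\C(=O)NCc2ccc(F)cc2)C(C)(C)CCC1n1ccnc1` differs from compound 2 by one swap (fluoro in place of hydroxy on an aromatic carbon) with fluoro in place of hydroxy on an aromatic carbon, para to a large group. For the measured compounds named here, the only measured step that bears on this is a 2.5-fold lower number from compound 1 to compound 2 (0.40 log units; beyond the scatter) where 4-hydroxybenzyl replaces 4-fluorophenyl. That modest step changes the hydroxy and the benzyl link together, so the data cannot split it. Compound 3 keeps the benzyl of compound 2 and takes the fluoro of compound 1, so at most part of that step should return in this assay as a higher number. The expected change is small: a 1.6-fold higher number from compound 2 to compound 3 (0.19 log units; within the scatter) in this estimate. For compound 3 the estimated value is 250 nM with an expected range from 100 nM to 600 nM in this assay.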

Compound 3, concentration for 50% growth inhibition: 1930 nM
For compound 3 the middle estimate is 7.7-fold (0.89 log units) below the measured one; measured number above the stated range.
By their numbers in this assay, from the lowest: compound 2; then compound 1; then compound 3.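

For the compounds shown here, with the benzyl link held fixed, the swap of hydroxy for fluoro in this assay gives a 12-fold higher number from compound 2 to compound 3 (1.08 log units; beyond the scatter), so the group at this position on the aromatic ring matters far more than the one earlier step could reveal. With the fluoro held fixed, 4-fluorobenzyl in place of 4-fluorophenyl gives a 4.8-fold higher number from compound 1 to compound 3 (0.68 log units; beyond the scatter), which means that the earlier step from compound 1 to compound 2 combined two changes pulling in opposite directions: the benzyl link raised the number here, while the hydroxy lowered it by more. Nothing measured here accounts for the size of either change. Going by these compounds, whether a methoxy or an amine at this position would keep a number as low as that of compound 2 remains open. Also open, on these data alone, is whether a 4-hydroxyphenyl amide, without the benzyl link, would read lower still.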